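Swapping phenyl for 1,3-thiazol-5-yl on a benzamide core

A few compounds are considered here, and "the series" means these few. Any claim that something is new, unique, unknown or untested is made for them only; others in the source may bear on it.

Measured compounds:
compound 1, `O=C(/C=C/c1cc(Cl)ccc1NC(=O)c1ccccn1)c1ccccc1`, 1700 nM
compound 2, `COc1ccc(NC(=O)c2ccccn2)c(CN2C(=O)c3ccccc3C2=O)c1`, 1400 nM
compound 3, `O=C(Nc1ccc(Cl)cc1CN1C(=O)c2ccccc2C1=O)c1ccccc1`, > 100000 nM

In an assay on CHO cells for positive allosteric modulation of metabotropic glutamate receptor 5 (Homo sapiens), read by FLIPR (a higher number here means that more compound is needed for the effect, a lower number that less compound is needed), compound 1 gives 1700 nM and compound 2 gives 1400 nM, two values that sit within the usual scatter of each other. Among the compounds with values here, compound 3 gives only a limit in this assay, > 100000 nM, so no number is known for it; it is the one compound sitting at the limit of > 100000 nM in this assay, at which 1 of the 3 values shown sits.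

Compound 4, `O=C(Nc1ccc(Cl)cc1CN1C(=O)c2ccccc2C1=O)c1cncs1`, is compound 3 with 1,3-thiazol-5-yl in place of phenyl on a carbonyl carbon. Since compound 3 has only a limit, the step from it cannot be measured against the other two, which differ from compound 3 in several places. Compound 4 is expected to reach a value of 20000 nM, between 3000 nM and 100000 nM, and the step of an at least 5.0-fold lower number from compound 3 to compound 4 (0.69 log units; beyond the scatter) is an estimate only, with a fair chance that the assay again reports just a limit.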

Compound 4, half-maximal effective concentration: 1900 nM
Beside the measured number, compound 4's estimate is 11-fold (1.02 log units) above it, and the stated range ends above it.
By their numbers in this assay, from the lowest: compounds 2, 1 and 4 (each within the scatter of the next). At a limit, above all of these: compound 3.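

Within the data shown here, for the first time a single change can be read: 1,3-thiazol-5-yl in place of phenyl on a carbonyl carbon gives an at least 52-fold lower number from compound 3 to compound 4 (1.72 log units; beyond the scatter) in this assay. On this core, then, the group on this carbonyl carbon can decide whether any effect is seen at all. Compound 3 has only a limit, so this step is a minimum: the limit of > 100000 nM in this assay, at which 1 of the 4 values shown sits.

Which part of the 1,3-thiazol-5-yl ring matters, its nitrogen, its sulfur or its five-membered shape, stays open. So does whether a thiophene ring, a furan ring or a plain methyl on the same carbonyl carbon would give a similar step.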